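The source may hold more compounds than are shown below. What is called first, only, known or untested is meant among the compounds shown, and "the series" means these compounds.

Measured compounds:
Compound 1 `O=C(c1ccc(OC(F)(F)F)cc1)N1CCC(N(C2CC2)S(=O)(=O)c2cccc(C(F)(F)F)c2)CC1`, 88% in an assay on cells for inhibition of Voltage-dependent L-type calcium channel subunit alpha-1C (Homo sapiens), read by FLIPR and calcium flux, tested at 3 uM; on this read-out higher numbers stand for a stronger effect at the one concentration tested and lower numbers for a weaker effect.
Compound 2 `O=C(c1ccccc1OC(F)(F)F)N1CCC(N(C2CC2)S(=O)(=O)c2cccc(C(F)(F)F)c2)CC1`, "not determined" (no result reported) in this assay.
Compound 3 `CN(C)c1cccc(C(=O)N2CCC(N(C3CC3)S(=O)(=O)c3cccc(C(F)(F)F)c3)CC2)c1`, 63% in this assay.

Compound 3 stands lowest of the two numbers available in this assay; its nearest neighbour is compound 1, whose number is higher by the step of a number 25 percentage points lower from compound 1 to compound 3 (beyond the scatter), which lies beyond the scatter. Compound 2 adds no number to the comparison.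

Compound 4 `O=C(c1cccc(OC(F)(F)F)c1)N1CCC(N(C2CC2)S(=O)(=O)c2cccc(C(F)(F)F)c2)CC1` is the next compound to be measured. It differs from compound 3 as follows: trifluoromethoxy in place of dimethylamino on an aromatic carbon. Going by the values given here, the one measured step that bears on this change is the move from compound 1 to compound 3, a number 25 percentage points lower from compound 1 to compound 3 (beyond the scatter), in which both the group and its position on the ring changed at once. The step to compound 4 keeps the position of compound 3 and brings in the group that compound 1 carries. A modest rise in this assay is therefore expected for compound 4, recovering part of the drop seen from compound 1 to compound 3, as the step of a number 15 percentage points higher from compound 3 to compound 4 (beyond the scatter). Compound 4 is estimated at 78%, with a range from 60% to 92%.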

Compound 4, a percentage reported as inhibition, at one concentration (the size of the read-out at that concentration, not a potency): 78%
For compound 4 middle estimate and measured number coincide at the digits printed; the range from low to high includes it.
By their numbers in this assay, from the lowest: compound 3; then compounds 4 and 1 (each within the scatter of the next).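

In this assay, the earlier step of a number 25 percentage points lower from compound 1 to compound 3 (beyond the scatter) changed the group and its ring position together, whereas the new step of a number 15 percentage points higher from compound 3 to compound 4 (beyond the scatter) changes only the group, with dimethylamino leaving and trifluoromethoxy entering at the same aromatic carbon, meta to a large group. The complementary step a number 10 percentage points lower from compound 1 to compound 4 (within the scatter) changes only the position of trifluoromethoxy, so among these compounds the group exchange gives a change beyond the scatter, while this move of the trifluoromethoxy group does not. No supporting data bear on why the exchange of dimethylamino for trifluoromethoxy changes the read-out.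

Compound 2 gives "not determined" (no result reported), so the placement of trifluoromethoxy it carries cannot be compared, and all of these results describe the effect at one concentration rather than potency. On these data alone, whether a carboxylic acid, a primary amine or a longer alkoxy chain on the same aromatic carbon would keep or lose the effect remains open.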